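Ester to Acid on the Shared Core of Compound 2

The source may hold more compounds than are shown below. What is called first, only, known or untested is meant among the compounds shown, and "the series" means these compounds.

Of the compounds shown here, three have so far been measured in an assay on isolated protein for inhibition of LIM domain kinase 1 (Homo sapiens), read by Kinase-Glo, with a stated time of 60 min; on this read-out lower numbers stand for stronger inhibition and higher numbers for weaker inhibition. Compound 1 `NNC(=O)c1sc2ncccc2c1N` gives only a limit of the assay, > 100000 nM. Compound 2 `CCOC(=O)c1sc2ccccc2c1N` likewise returns only a limit, > 100000 nM. Two of the three values thus sit at the limit of > 100000 nM in this assay, at which 2 of the 3 values shown sit. Within the data shown here, compound 3 `Cc1ccc(-c2cc(C(F)(F)F)c3c(N)c(C(N)=O)sc3n2)o1` is the one compound with a number, giving 41000 nM in this assay.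

The unmeasured compound 4 `Nc1c(C(=O)O)sc2ccccc12` differs from compound 2 by hydrogen in place of ethyl on an oxygen next to a carbonyl group, in words hydrogen in place of ethyl on an oxygen next to a carbonyl group. Among the measured compounds shown here, no step between two measured compounds is available, so the size of this change cannot be read from any neighbouring pair. Since compound 2 gives only the limit > 100000 nM, no measurable inhibition is expected for compound 4 either. Compound 4 is expected to give about 100000 nM, within 30000 nM to 300000 nM, most likely again as a limit. The expected step of a number no higher from compound 2 to compound 4 (the limit leaves the size open) is estimated to lie within the scatter.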

Compound 4, half-maximal inhibitory concentration: > 100000 nM
Compound 4 ended at the assay's limit (the forecaster's own chance of this, stated with the estimate: 80%); the middle value sits exactly at the limit.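

Compound 2 and compound 4 both stand at a limit, so no step between them can be read: the limit of > 100000 nM in this assay, at which 3 of the 4 values shown sit.

The compounds shown leave open how strongly either compound inhibits in this assay, and whether hydrogen in place of ethyl changes the value at all.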